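The source may report more compounds than this note shows. Statements on the series, on what has been measured and on what is new or still open speak of the compounds shown alone.

Measured in a functional assay on Rec1 cells (Homo sapiens) for inhibition, read by luminescence and CellTiter-Glo, with a stated time of 72 h; on this read-out lower numbers stand for stronger inhibition and higher numbers for weaker inhibition:

- Compound 1 `O=C(CCl)Nc1ccc(Cn2nc(-c3ccc(Oc4ccccc4)cc3)cc2CO)cc1`: 400 nM
- Compound 2 `C/C=C/C(=O)Nc1cccc(Cn2nc(-c3ccc(Oc4ccccc4)cc3)cc2C(=O)O)c1`: 26000 nM
- Compound 3 `C/C=C/C(=O)N1CCCC(n2nc(-c3ccc(Oc4ccccc4)cc3)cc2C(=O)OCC)C1`: 5100 nM

Of these three, compound 2 has the highest number and is the weakest, at 26000 nM. Compound 4 `C/C=C/C(=O)Nc1cccc(Cn2nc(-c3ccc(Oc4ccccc4)cc3)cc2C(=O)OCC)c1` differs from compound 2 by one change (ethyl in place of hydrogen on an oxygen next to a carbonyl group), with ethyl in place of hydrogen on an oxygen next to a carbonyl group, so that carboxy becomes ethoxycarbonyl. Among the compounds with values here, no measured pair isolates this change. Compound 3 also carries ethoxycarbonyl, though it differs elsewhere, and it stands at 5100 nM. A step to a lower number, beyond the scatter, is therefore expected in this assay, and the expected size is a 7.4-fold lower number from compound 2 to compound 4 (0.87 log units; beyond the scatter). The estimate for compound 4 is 3500 nM, within an expected range of 1000 nM to 12000 nM.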

Compound 4, half-maximal inhibitory concentration: 7800 nM
For compound 4 the middle estimate is 2.2-fold (0.35 log units) below the measured one; measured number inside the range.
By their numbers in this assay, from the lowest: compound 1; then compounds 3 and 4 (each within the scatter of the next); then compound 2.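

Within the data shown here, this pair isolates the change for the first time: in this assay, ethyl in place of hydrogen on an oxygen next to a carbonyl group gives a 3.3-fold lower number from compound 2 to compound 4 (0.52 log units; beyond the scatter). On this core, then, ethoxycarbonyl gives a lower number than carboxy, though the step is only modest. Nothing measured here accounts for this step.

As far as these compounds go, whether a methyl ester, a longer chain on the oxygen or a primary amide would give a lower number at this place remains open. So does whether the change from carboxy to ethoxycarbonyl gives a step of similar size on the core of compound 3.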